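From 4-Fluorobenzyl to 4-Chlorobenzyl: One Unmeasured Step

The source may hold more compounds than are shown below. What is called first, only, known or untested is meant among the compounds shown, and "the series" means these compounds.

Compound 1 `CCOC(=O)N1[C@@H]2C=C[C@@](OC)(C(=O)c3c2cc(OC)c(OC)c3OCc2ccc(F)cc2)N1C(=O)OCC`: 51.8 ug/mL
Compound 2 `COC(=O)N1[C@@H]2C=C[C@@](OC)(C(=O)c3c2cc(OC)c(OC)c3OCc2ccc(Cl)cc2)N1C(=O)OC`: 55.9 ug/mL

In an ADME assay on KB cells (Homo sapiens) for cytotoxicity (a higher number here means that more compound is needed for the effect, a lower number that less compound is needed), compound 1 gives 51.8 ug/mL and compound 2 gives 55.9 ug/mL. These two values lie within the usual scatter of each other, so compound 1 cannot be told apart from compound 2 on these numbers. Still unmeasured is compound 3 `CCOC(=O)N1[C@@H]2C=C[C@@](OC)(C(=O)c3c2cc(OC)c(OC)c3OCc2ccc(Cl)cc2)N1C(=O)OCC`, which differs from compound 1 at a single place: chloro in place of fluoro on an aromatic carbon, para to a large group (chloro in place of fluoro on an aromatic carbon). Among the measured compounds shown here, no measured pair shows this exchange directly, so the expectation rests on little. With compound 1 at 51.8 ug/mL and compound 2 at 55.9 ug/mL so close, no step beyond the scatter is expected. The expected step is small (a 1.0-fold higher number from compound 1 to compound 3 (0.00 log units; within the scatter)). For compound 3 the estimate is 52 ug/mL (expected range 30 ug/mL to 85 ug/mL).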

Compound 3, concentration for half-maximal effect: 99.9 ug/mL
Compound 3: the middle estimate sits 1.9-fold (0.28 log units) below what was measured, and the stated range ends below it.
By their numbers in this assay, from the lowest: compounds 1, 2 and 3 (each within the scatter of the next).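

In this assay, among the compounds shown here, chloro in place of fluoro on an aromatic carbon, para to a large group, gives a 1.9-fold higher number from compound 1 to compound 3 (0.29 log units; within the scatter) and so provides the first direct reading of this exchange on the core of compound 1. The step lies within the scatter, so compound 1 and compound 3 cannot be told apart, and at this position the two halogens give no distinguishable read-out in this assay. Nothing available here bears on the origin of this result.

Only fluoro and chloro appear at this position among the compounds shown, so it remains open how an amine or a carboxylic acid there would read in this assay. Also open, as far as these compounds go, is whether a longer chain in place of the 4-chlorobenzyl group would move the number beyond the scatter.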